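This account rests on a few compounds, and the source may have more. Where it says the series, first, only, none or still open, it means among the compounds named here.

Measured so far:
compound 1, `Nc1ccccc1NC(=O)/C=C/c1ccc(CSc2ccc(Cl)cc2)cc1`, 13.4%
compound 2, `Nc1ccccc1NC(=O)c1ccc(CSc2ccc(C(F)(F)F)cn2)cc1`, 4.3%
compound 3, `COc1ccc(SCc2ccc(C(=O)Nc3ccccc3N)cc2)cc1`, 10.2%

In a functional assay on A-375 cells (Homo sapiens) for inhibition, read by CCK-8 assay, with a stated time of 72 h, tested at 2 uM (a higher number here means more inhibition of growth at the concentration tested, a lower number less inhibition of growth), compound 1 gives 13.4%, the highest of the three numbers shown. Its nearest neighbour is compound 3 with 10.2%, and the furthest is compound 2 with 4.3%; both of these gaps lie within the usual scatter of the measurement, so the three compounds cannot be placed in any order on these numbers.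

The step from compound 1 to the unmeasured compound 4, `Nc1ccccc1NC(=O)/C=C/c1ccc(CSc2ccc(C(F)(F)F)cn2)cc1`, is 5-(trifluoromethyl)pyridin-2-yl in place of 4-chlorophenyl on a sulfur. No pair of measured compounds differs in exactly this way, so the size of the step is not shown by any measured pair. Compound 2 carries the same entering group on sulfur but on a different core, and its value of 4.3% is within the scatter of compound 1. On that basis a step of no more than the scatter is expected, in either direction, with a slight lean downward given that compound 2 shows 4.3%.

For compound 4 in this assay the estimate is 9%, with a range from 0% to 22%, meaning an expected step of a number 4.4 percentage points lower from compound 1 to compound 4 (within the scatter).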

Compound 4, percent growth inhibition at one concentration: 10.3%
Compound 4: the middle estimate sits 1.3 percentage points below what was measured; the range from low to high includes it.
By their numbers in this assay, from the lowest: compounds 2, 3, 4 and 1 (each within the scatter of the next).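

In this assay, among the compounds shown here, putting 5-(trifluoromethyl)pyridin-2-yl in place of 4-chlorophenyl on a sulfur gives a number 3.1 percentage points lower from compound 1 to compound 4 (within the scatter) and provides the first measured single-place step at this position. The exchange of a ring of carbon only for a larger ring group with one hetero atom therefore leaves no difference that can be told from the scatter of this read-out. This holds only for these two groups on the core of compound 1, and it gives no direction for the position.

Going by these compounds, whether an amine or a carboxylic acid on this ring, or a longer saturated chain on the sulfur in place of the ring, would give a step beyond the scatter remains open. Nothing measured here explains the result of this exchange.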